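The source may hold more compounds than are shown below. What is called first, only, known or untested is meant among the compounds shown, and "the series" means these compounds.

Measured in an assay on isolated protein for displacement of a labelled ligand from Apoptosis regulator Bcl-2 (Homo sapiens), with a stated time of 15 min; on this read-out higher numbers stand for weaker inhibition and lower numbers for stronger inhibition:
compound 1 `CC1(C)CCC(CN2CCN(c3ccc(C(=O)NS(=O)(=O)c4ccc(NCC5CCOCC5)c([N+](=O)[O-])c4)c(Oc4cnc5[nH]ccc5c4)c3)CC2)=C(c2ccc(Cl)cc2C(F)(F)F)C1` — 0.86 nM
compound 2 `COc1ccc(C2=C(CN3CCN(c4ccc(C(=O)NS(=O)(=O)c5ccc(NCC6CCOCC6)c([N+](=O)[O-])c5)c(Oc5cnc6[nH]ccc6c5)c4)CC3)CCC(C)(C)C2)cc1` — 3.8 nM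
compound 3 `CN(C)CCCNc1ccc(S(=O)(=O)NC(=O)c2ccc(N3CCN(CC4=C(c5ccc(C(F)(F)F)cc5)CC(C)(C)CC4)CC3)cc2Oc2cnc3[nH]ccc3c2)cc1[N+](=O)[O-]` — 0.89 nM

Compound 3 holds the second highest of the three numbers in this assay; its number and that of compound 1 lie within the scatter of each other, while compound 2 sits beyond the scatter at the higher end. For the measured compounds named here, the only single-change step, a 4.4-fold higher number from compound 1 to compound 2 (0.65 log units; beyond the scatter), concerns the aryl group on the double-bonded ring carbon and says nothing about the amine side chain. Compound 4 `CC1(C)CCC(CN2CCN(c3ccc(C(=O)NS(=O)(=O)c4ccc(NCC5CCOC5)c([N+](=O)[O-])c4)c(Oc4cnc5[nH]ccc5c4)c3)CC2)=C(c2ccc(C(F)(F)F)cc2)C1` differs from compound 3 in exactly that side chain: oxolan-3-yl in place of 2-(dimethylamino)ethyl on a saturated chain carbon bound to a nitrogen on an aromatic ring. Going by the values given here, no measured pair varies this position, so no direction can be read from the data, and a step within the scatter is expected, a 1.1-fold higher number from compound 3 to compound 4 (0.05 log units; within the scatter). Compound 4 is accordingly estimated at 1 nM, in the range 0.4 nM to 2.5 nM.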

Compound 4, half-maximal inhibitory concentration: 4.7 nM
Compound 4: the middle estimate sits 4.7-fold (0.67 log units) below what was measured, outside the stated range (above it).
By their numbers in this assay, from the lowest: compounds 1 and 3 (each within the scatter of the next); then compounds 2 and 4 (each within the scatter of the next).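

In this assay the amine side chain proves to be a position that responds: oxolan-3-yl in place of 2-(dimethylamino)ethyl gives a 5.3-fold higher number from compound 3 to compound 4 (0.72 log units; beyond the scatter) while heavy-atom, donor and acceptor counts stay the same. For the compounds shown here, the earlier step varied only the aryl group, so this is the first reading at this position. Nothing available bears on the reason for this shift.

The change swaps both ring for open chain and oxygen for nitrogen, so neither is separated from the other. An open-chain 2-methoxyethyl or a nitrogen-bearing piperidine ring at this place would separate them.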